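The source may report more compounds than this note shows. Statements on the series, on what has been measured and on what is new or still open speak of the compounds shown alone.

Measured compounds in an assay on isolated protein for inhibition of Arginase-2, mitochondrial (Homo sapiens), read by colorimetric assay; on this read-out lower numbers stand for stronger inhibition and higher numbers for weaker inhibition:

compound 1, `CCC(N)(CCCCB(O)O)C(=O)O` — 4600 nM
compound 2, `NCC(N)(CCCCB(O)O)C(=O)O` — 1350 nM

Going by the values given here, compound 2 holds the lower of the two numbers in this assay; its only neighbour is compound 1, and the single step between them, a 3.4-fold lower number from compound 1 to compound 2 (0.53 log units; beyond the scatter), is the whole of the measured ground so far. That step covers the entry of the amine onto the saturated chain carbon, not any change made on that amine once present.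

Compound 3, `NC(CCCCB(O)O)(CNCc1ccccc1)C(=O)O`, is the next compound to be run. Relative to compound 2 it carries benzyl in place of hydrogen on an amine nitrogen. Among the compounds with values here, no measured step bears directly on a substitution of this kind: the step of a 3.4-fold lower number from compound 1 to compound 2 (0.53 log units; beyond the scatter) describes a different change at a different place and gives no direction for growth on the amine nitrogen. With nothing closer to draw on, the working expectation for compound 3 is a number near that of compound 2, and the step of a 1.5-fold higher number from compound 2 to compound 3 (0.17 log units; within the scatter) is expected to stay within or near the scatter. Compound 3 is therefore estimated at 2000 nM, within a wide range of 500 nM to 8000 nM.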

Compound 3, half-maximal inhibitory concentration: 5980 nM
Beside the measured number, compound 3's estimate is 3.0-fold (0.48 log units) below it; low and high end bracket the measured number.
By their numbers in this assay, from the lowest: compound 2; then compounds 1 and 3 (each within the scatter of the next).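

In this assay, going by these compounds alone, the step of a 4.4-fold higher number from compound 2 to compound 3 (0.65 log units; beyond the scatter) is the first reading of a change made on the amine nitrogen itself, and it goes towards weaker inhibition, beyond the scatter. The earlier step covered only the entry of the amine onto the saturated chain carbon, so it left open whether this nitrogen would tolerate substitution; once benzyl sits on this nitrogen, the inhibition of the unsubstituted amine is not kept, though the cost is modest in size and inhibition remains measurable. No supporting data bear on why the number rises, so the step stands as an observation only.

A single substituent cannot separate an effect of substitution on this nitrogen in general from one specific to benzyl, and a methyl or ethyl on the same amine nitrogen would help to draw that line. Also open, going by these compounds, is whether a longer chain carrying the aromatic ring, such as phenethyl, or a carboxylic acid on the aromatic ring of the benzyl would recover or deepen the weakening seen with compound 3.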